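Trimming an Amide Substituent on a Shared Core

A few compounds are considered here, and "the series" means these few. Any claim that something is new, unique, unknown or untested is made for them only; others in the source may bear on it.

Compound 1, `CC[C@@H]1C(=O)N(C)c2cnc(Nc3ccc(S(N)(=O)=O)cc3)nc2N1C1CCCC1`: 3390 nM
Compound 2, `CCC1C(=O)N(C)c2cnc(Nc3ccc(S(=O)(=O)NCC(C)C)cc3)nc2N1c1ccn(C)n1`: 31600 nM
Compound 3, `CC[C@@H]1C(=O)N(C)c2cnc(-n3ccc4cc(C(=O)NC(C)C)ccc43)nc2N1C1CCCC1`: 1780 nM

These three compounds were tested in a functional assay on A549 cells (Homo sapiens) for antiproliferative activity, read by CCK-8 assay, with a stated time of 72 h; on this read-out lower numbers stand for stronger inhibition of growth and higher numbers for weaker inhibition of growth. Compound 3 shows the lowest number of the three. Its gap to compound 1 is within the usual scatter, so no order between these two can be claimed. Its gap to compound 2 lies beyond the scatter, so compound 3 inhibits growth more strongly than compound 2.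

Compound 4, `CC[C@@H]1C(=O)N(C)c2cnc(-n3ccc4cc(C(=O)NC)ccc43)nc2N1C1CCCC1`, differs from compound 3 in one place only: methyl in place of isopropyl on an amide-type nitrogen. Going by the values given here, no measured pair shows this same change, so nothing in the data tells how much such a trimming shifts the read-out. With a change this small, the step is expected to stay within the scatter, with no clear direction. The expected step of a 1.2-fold higher number from compound 3 to compound 4 (0.09 log units; within the scatter) is accordingly small in this assay. Compound 4 is therefore estimated to give 2200 nM in this assay, with a range from 900 nM to 5500 nM.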

Compound 4, concentration for 50% growth inhibition: 2200 nM
Compound 4: middle estimate and measured number agree at the digits printed; the range from low to high includes it.
By their numbers in this assay, from the lowest: compounds 3, 4 and 1 (each within the scatter of the next); then compound 2.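

In this assay putting methyl in place of isopropyl on the amide-type nitrogen gives a 1.2-fold higher number from compound 3 to compound 4 (0.09 log units; within the scatter) and so stays within the scatter, which means no order between these two compounds can be claimed. Going by these compounds alone, the earlier compounds offered no pair differing in one place, so this is the first direct reading of this position: here, exchanging these two groups leaves no clear mark on growth inhibition. No supporting measurement is available to explain why the step is this small.

Still open, on these data alone, is whether a longer chain on this nitrogen, or one ending in an amine or a carboxylic acid, would shift the read-out beyond the scatter. Also open, as far as these compounds go, is whether the same trimming would stay this small on a different core.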